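The source may report more compounds than this note shows. Statements on the series, on what has been measured and on what is new or still open speak of the compounds shown alone.

Measured in a functional assay on MGC-803 cells (Homo sapiens) for inhibition, read by MTT assay, with a stated time of 72 h; on this read-out lower numbers stand for stronger inhibition and higher numbers for weaker inhibition
- Compound 1 (`Cc1cc(Nc2cc(-c3ccccc3)[nH]n2)n2nc(SCCc3ccccc3)nc2n1`) gives 5620 nM
- Compound 2 (`Cc1ccc(CSc2nc3nc(C)cc(Nc4cc(-c5ccccc5)[nH]n4)n3n2)cc1`) gives 6960 nM

Among the measured compounds shown here, compound 2 stands within the scatter of its only measured neighbour, with a 1.2-fold higher number from compound 1 to compound 2 (0.09 log units; within the scatter). Compound 3 (`Cc1cc(Nc2cc(-c3ccccc3)[nH]n2)n2nc(SCC3CC3)nc2n1`) carries cyclopropyl in place of 4-methylphenyl on a saturated chain carbon bound to a sulfur. That one measured step changed the same substituent, but both measured compounds keep a six-membered aromatic ring there, so the data do not cover its loss. No shift beyond the scatter is therefore expected in this assay, though with wide uncertainty. The expected change is a 1.1-fold higher number from compound 2 to compound 3 (0.06 log units; within the scatter). Compound 3 is estimated at 8000 nM, with an expected range of 3000 nM to 22000 nM.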

Compound 3, half-maximal inhibitory concentration: 16100 nM
Compound 3: middle estimate off by 2.0-fold (0.30 log units), on the low side, within the range that was stated.
By their numbers in this assay, from the lowest: compounds 1 and 2 (each within the scatter of the next); then compound 3.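

In this assay, losing the six-membered aromatic ring on a saturated chain carbon bound to a sulfur has a modest effect beyond the scatter, with cyclopropyl in place of 4-methylphenyl (a 2.3-fold higher number from compound 2 to compound 3 (0.36 log units; beyond the scatter)) and in place of benzyl (a 2.9-fold higher number from compound 1 to compound 3 (0.46 log units; beyond the scatter)). This position therefore responds to the change of group, which the step between the two aromatic compounds did not show. Nothing available accounts for this difference.

Cyclopropyl differs from both earlier groups in ring type and in heavy-atom count, so the compounds shown do not separate these two changes. Cyclohexyl, a saturated carbon ring of six, would bear directly on that question.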